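The compounds below may be only part of what the source reports. "The series", "measured", "known", "first", "only" and "open" are said of these compounds alone.

Of the compounds shown here, three sharing one core have been tested in a functional assay on MDA-MB-231 cells (Homo sapiens) for inhibition, read by sulforhodamine B assay, with a stated time of 48 h (a higher number here means a weaker inhibitor of growth, a lower number a stronger inhibitor of growth), and they differ at a single aromatic carbon. Compound 1 `COc1ccc2c(c1)NC(=O)CN2c1nc(COCCCC(=O)NO)nc2ccccc12`, which carries (3-(hydroxycarbamoyl)propoxy)methyl there, gives 1020 nM. Compound 2 `COc1ccc2c(c1)NC(=O)CN2c1nc(NC2CC2)nc2ccccc12`, with cyclopropylamino, gives 10.5 nM. Compound 3 `COc1ccc2c(c1)NC(=O)CN2c1nc(NCc2ccncc2)nc2ccccc12`, with ((pyridin-4-yl)methyl)amino, gives 73.6 nM, the middle number of the three.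

Compound 4 `CCOc1nc(N2CC(=O)Nc3cc(OC)ccc32)c2ccccc2n1` has ethoxy in place of ((pyridin-4-yl)methyl)amino on the aromatic carbon between two ring nitrogen atoms: ethoxy in place of ((pyridin-4-yl)methyl)amino on an aromatic carbon.

Earlier changes at this carbon show that it matters. Replacing the long chain gave a 97-fold lower number from compound 1 to compound 2 (1.99 log units; beyond the scatter) with cyclopropylamino and a 14-fold lower number from compound 1 to compound 3 (1.14 log units; beyond the scatter) with ((pyridin-4-yl)methyl)amino. Exchanging the two amino groups gave a 7.0-fold higher number from compound 2 to compound 3 (0.85 log units; beyond the scatter). None of the tested compounds has an oxygen joined directly to this carbon, so the guidance is indirect and the uncertainty is wide. Ethoxy has no aromatic ring, and neither does the cyclopropylamino group, whose presence goes with the lower number in a 7.0-fold higher number from compound 2 to compound 3 (0.85 log units; beyond the scatter). That single pair points to a small move toward a lower number in this assay. The expected change is a 1.8-fold lower number from compound 3 to compound 4 (0.26 log units; within the scatter). For compound 4 the estimated value is 40 nM, with an expected range from 8 nM to 200 nM.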

Compound 4, concentration for 50% growth inhibition: 15.4 nM
Compound 4: middle estimate off by 2.6-fold (0.41 log units), on the high side, within the range that was stated.
By their numbers in this assay, from the lowest: compounds 2 and 4 (each within the scatter of the next); then compound 3; then compound 1.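

In this assay, an oxygen-linked group on this aromatic carbon can match a nitrogen-linked one: putting ethoxy in place of cyclopropylamino gives a 1.5-fold higher number from compound 2 to compound 4 (0.17 log units; within the scatter), so compound 2 and compound 4 cannot be told apart. Removing the aromatic ring of ((pyridin-4-yl)methyl)amino by the change to ethoxy gives a 4.8-fold lower number from compound 3 to compound 4 (0.68 log units; beyond the scatter), a second pair in which the group without an aromatic ring has the lower number, but compound 1 goes against any simple rule, since its long chain also has no aromatic ring and the change to ethoxy gives a 66-fold lower number from compound 1 to compound 4 (1.82 log units; beyond the scatter). Nothing measured here explains this order.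

These compounds do not separate the effect of the linking atom from that of the attached group, and ethylamino, which carries the same two-carbon chain on nitrogen, would make that comparison directly. Methoxy, a longer chain such as butoxy, and phenoxy, which puts an aromatic ring on the oxygen, would show how far this tolerance extends.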